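Fluoro for methyl on the core of compound 1

The source may report more compounds than this note shows. Statements on the series, on what has been measured and on what is new or still open speak of the compounds shown alone.

Compound 1 `Cc1ccc2c(c1)c(Sc1ccc(Cl)cc1)c(C)n2CC(=O)O`: in an in vitro ADME assay on microsomes from liver (Homo sapiens) for metabolic stability (on this read-out higher numbers stand for fast clearance and lower numbers for slow clearance), compound 1 gives a limit of < 3 mL.min-1.g-1.
Compound 2 `Cc1c(Sc2ccc(Cl)cc2)c2c(-c3nccs3)cccc2n1CC(=O)O`: compound 2 gives 43 mL.min-1.g-1.
Compound 3 `COc1ccc(Sc2c(C)n(CC(=O)O)c3ccc(C)cc23)cc1`: compound 3 gives a limit of < 3 mL.min-1.g-1.

Compound 1 stands at the lower limit of the assay, so its result is a limit rather than a number. Compound 3 sits at the same limit, which is the limit of < 3 mL.min-1.g-1 in this assay, at which 2 of the 3 values shown sit. Only compound 2 carries a numeric value. For the measured compounds named here, the single one-change step between measured compounds, a step that the two limits leave unreadable from compound 1 to compound 3, cannot be read in size, since both of its ends are limits.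

Compound 4 `Cc1c(Sc2ccc(Cl)cc2)c2cc(F)ccc2n1CC(=O)O` differs from compound 1 by fluoro in place of methyl on an aromatic carbon. Going by the values given here, no measured step shows this change, and the one measured step gives no readable size, so nothing here points to a step beyond the scatter in either direction. Compound 1 is expected to remain the nearest guide, with compound 4 expected to sit close to the limit where compound 1 stands, that is an at least 1.3-fold higher number from compound 1 to compound 4 (0.12 log units; that floor lies within the scatter). Compound 4 is therefore estimated at 4 mL.min-1.g-1, between 1 mL.min-1.g-1 and 12 mL.min-1.g-1.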

Compound 4, intrinsic clearance in microsomes: < 3 mL.min-1.g-1
Compound 4 ended at the assay's limit (the forecaster's own chance of this, stated with the estimate: 55%); at least 1.3-fold (0.12 log units) between middle value and limit.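

Compound 1 and compound 4 both stand at a limit in this assay, and the step between them cannot be read. The compounds shown leave open whether fluoro in place of methyl on an aromatic carbon shifts clearance at all, with most values resting at one limit: the limit of < 3 mL.min-1.g-1 in this assay, at which 3 of the 4 values shown sit.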